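Methoxy Enters the Benzoyl Ring of Compound 2

The source may hold more compounds than are shown below. What is called first, only, known or untested is meant among the compounds shown, and "the series" means these compounds.

Of the compounds shown here, three built on one shared core have been measured in an assay on MDA-MB-231 cells for binding affinity to C-X-C chemokine receptor type 4 (Homo sapiens), read by immunofluorescence and microscopy, with stated times of 10 min and 30 min; on this read-out lower numbers stand for an effect already at smaller amounts and higher numbers for an effect only at larger amounts of compound. Compound 1 `O=C(NCc1ccc(CNS(=O)(=O)c2ccccc2)cc1)c1cccc(F)c1` gives 100 nM. Compound 3 `Cc1ccc(S(=O)(=O)NCc2ccc(CNC(=O)c3ccc(Cl)cc3)cc2)cc1` gives 10 nM. Compound 2 `Cc1ccc(S(=O)(=O)NCc2ccc(CNC(=O)c3ccccc3)cc2)cc1` reaches only a limit of the assay, > 1000 nM, so no definite number is known for it. Among the values shown, compound 2 is thus the one that sits at the limit of > 1000 nM in this assay, at which 1 of the 3 values shown sits, rather than at a measured point.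

Compound 4 `COc1ccccc1C(=O)NCc1ccc(CNS(=O)(=O)c2ccc(C)cc2)cc1` has not yet been measured. It differs from compound 2 by methoxy in place of hydrogen on an aromatic carbon. Going by the values given here, one measured step touches the same ring: an at least 100-fold lower number from compound 2 to compound 3 (2.00 log units; beyond the scatter), where a single chloro group in place of hydrogen moved the number a long way. Methoxy is a different group placed on a different aromatic carbon, so a gain of that size is not assumed, but some movement beyond the scatter in the same direction is expected. The expected value for compound 4 is 300 nM, between 30 nM and 3000 nM, which would mean an at least 3.3-fold lower number from compound 2 to compound 4 (0.52 log units; beyond the scatter).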

Compound 4, effective concentration (reported as EC, without a stated level of effect): 100 nM
Beside the measured number, compound 4's estimate is 3.0-fold (0.48 log units) above it; measured number inside the range.
By their numbers in this assay, from the lowest: compound 3; then compounds 1 and 4 (each within the scatter of the next). At a limit, above all of these: compound 2.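

In this assay, going by these compounds alone, methoxy ortho to a large group brings an at least 10-fold lower number from compound 2 to compound 4 (1.00 log units; beyond the scatter), so chloro is no longer the only group on this benzoyl ring that comes with a lower number. From the compounds shown here alone, the true size of that step remains unknown, since compound 2 stands at a limit: the limit of > 1000 nM in this assay, at which 1 of the 4 values shown sits. Placing 2-methoxyphenyl where 4-chlorophenyl stood gives a 10-fold higher number from compound 3 to compound 4 (1.00 log units; beyond the scatter), but the group and its place on the ring change together in that step, so their shares cannot be separated.

Still open, going by these compounds, is what chloro would give ortho to a large group, and what methoxy would give on the carbon that holds chloro in compound 3. Also open, on these data alone, is whether an amine or a carboxylic acid on this ring would give a lower number too.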